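The compounds below may be only part of what the source reports. "The series", "measured", "known", "first", "only" and "open" are said of these compounds alone.

Working notes on the series. Compound 1 `O=C(C=CNc1cc(-c2ccccc2)nn1-c1ccccc1)c1ccc(Cl)cc1` is the reference point here. In a functional assay on HepG2 cells (Homo sapiens) for inhibition, read by MTT assay, with a stated time of 48 h (on this read-out higher numbers stand for weaker inhibition and lower numbers for stronger inhibition), compound 1 gives 41200 nM, the second highest of the three numbers recorded. Compound 2 `Brc1ccc(-c2ccnc3c2c(-c2ccccc2)nn3-c2ccccc2)cc1` gives in this assay 49900 nM, and the two values lie within the scatter of each other, so no order between compound 1 and compound 2 can be read from them. Compound 3 `COc1ccc(-c2nc3c(c(-c4ccccc4)nn3-c3ccccc3)c(-c3ccc(N4CCN(C)CC4)cc3)c2C#N)cc1`, built on a different core and carrying a methoxyphenyl among its substituents, gives in this assay 1330 nM, a number beyond the scatter from that of compound 1 and the lowest in the set; with no single-point difference between compound 3 and compound 1, its value only shows what the series can reach.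

Compound 4 `COc1ccc(C(=O)C=CNc2cc(-c3ccccc3)nn2-c2ccccc2)cc1` is the next compound to be measured. It differs from compound 1 in one place: methoxy in place of chloro on an aromatic carbon. Among the measured compounds shown here, no measured pair isolates this exchange, so the data say nothing about how large a step it brings or in which direction. The expectation is a step of a 1.0-fold lower number from compound 1 to compound 4 (0.01 log units; within the scatter), that is, none beyond the scatter. For compound 4 the expected value in this assay is 40000 nM, with a range from 15000 nM to 110000 nM.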

Compound 4, half-maximal inhibitory concentration: 2030 nM
Beside the measured number, compound 4's estimate is 20-fold (1.29 log units) above it; the measured number lies below the stated range.
By their numbers in this assay, from the lowest: compounds 3 and 4 (each within the scatter of the next); then compounds 1 and 2 (each within the scatter of the next).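

In this assay, among the compounds shown here, the place on the aromatic ring of compound 1 para to a large group proves sensitive: methoxy in place of chloro gives a 20-fold lower number from compound 1 to compound 4 (1.31 log units; beyond the scatter) and is the first single exchange that can be read. The step is beyond the scatter, and since nothing else differs between the two structures, it belongs to the passage from 4-chlorophenyl to 4-methoxyphenyl, in which a group without a hydrogen-bond acceptor gives way to one with a hydrogen-bond acceptor. No measurement at hand bears on the reason for a step of this size, so it stands as an observation only.

A single pair cannot show whether the step is specific to methoxy or would also appear with a hydroxyl, an ethoxy or a dimethylamino group in the same place. As far as these compounds go, it also remains open whether the same exchange would bring a step of similar size on the core of compound 2 or that of compound 3.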